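Swapping the aryl ketone terminus on a chalcone-amide core

The compounds below may be only part of what the source reports. "The series", "measured", "known", "first", "only" and "open" are said of these compounds alone.

Compound 2 `COC(=O)c1cc(-c2cccc(NC(=O)c3ccc(/C=C/C(=O)c4ccc(F)cc4F)cc3)c2)on1` carries a shared core in which a 2,4-difluorophenyl sits on the carbonyl carbon of the chain. In an ADME assay on Vero cells (Chlorocebus sabaeus) for cytotoxicity, read by MTT assay, with a stated time of 72 h (on this read-out lower numbers stand for higher toxicity in this test and higher numbers for lower toxicity in this test), compound 2 reaches only a limit, > 40 ug/mL. Compound 1 `COC(=O)c1cc(-c2cccc(NC(=O)c3ccc(/C=C/C(=O)c4cccc(C(F)(F)F)c4)cc3)c2)on1` differs from it only in having 3-(trifluoromethyl)phenyl on that carbonyl carbon. In this assay compound 1 likewise gives a limit, > 20 ug/mL. The step that the two limits leave unreadable from compound 1 to compound 2 is therefore not readable, since both values stand at limits (the limit of > 20 ug/mL in this assay, at which 1 of the 2 values shown sits, and (the limit of > 40 ug/mL in this assay, at which 1 of the 2 values shown sits)), and it offers no measured size to carry forward.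

Compound 3 `COC(=O)c1cc(-c2cccc(NC(=O)c3ccc(/C=C/C(=O)c4ccc(OC)c([N+](=O)[O-])c4)cc3)c2)on1` is not yet measured. It differs from compound 2 as follows: 4-methoxy-3-nitrophenyl in place of 2,4-difluorophenyl on a carbonyl carbon. For the measured compounds named here, no measured step bears on this change, because the only step available, a step that the two limits leave unreadable from compound 1 to compound 2, lies between two limits. With both measured compounds sitting at limits in this assay, compound 3 is expected to behave similarly, and the step of a number no higher from compound 2 to compound 3 (the limit leaves the size open) is estimated to be none beyond the scatter. Compound 3 is accordingly estimated at 40 ug/mL in this assay, with a range from 15 ug/mL to 100 ug/mL, and a further limit rather than a number is considered likely.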

Compound 3, half-maximal cytotoxic concentration: > 40 ug/mL
Compound 3: only a limit was reported; the forecaster's own chance of this, stated with the estimate: 65%; the middle value lies on the limit itself.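

In this assay compound 3 gives > 40 ug/mL, which is a limit and not a number. For the compounds shown here, compound 1, compound 2 and compound 3 all stand at limits, so no step among them can be read. The compounds shown leave open whether the group on the carbonyl carbon changes the half-maximal cytotoxic concentration in this assay, and by how much.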